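Adding a Methoxy Group to Compound 3

The source may hold more compounds than are shown below. What is called first, only, known or untested is meant among the compounds shown, and "the series" means these compounds.

Compound 3, with `COc1ccccc1-c1nc(Cc2c[nH]c3ccccc23)no1`, sits at the high end of the measured numbers. In a functional assay on cells (Splenocyte, Mus musculus, strain BALB/c) for inhibition, read by scintillation counting and thymidine incorporation, with stated times of 48 h and 8 h (on this read-out higher numbers stand for weaker inhibition and lower numbers for stronger inhibition), compound 3 gives 11100 nM. Compound 1, with `COc1cc(-c2noc(Cc3c[nH]c4ccccc34)n2)cc(OC)c1OC`, gives 2800 nM in this assay, a lower number whose gap to compound 3 lies beyond the usual scatter. Compound 2, with `Clc1ccc(-c2noc(Cc3c[nH]c4ccccc34)n2)cc1`, is reported in this assay only as a limit of > 50000 nM, not as a number (the limit of > 50000 nM in this assay, at which 1 of the 3 values shown sits). Among the numbers actually measured, compound 3 therefore carries the highest.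

Compound 4, with `COc1ccc(-c2nc(Cc3c[nH]c4ccccc34)no2)c(OC)c1`, differs from compound 3 by a single change: methoxy in place of hydrogen on an aromatic carbon. Going by the values given here, no measured pair shows this change on its own, so its size cannot be read from a measured step. Among the compounds with values here, the only guide is compound 1, which carries further methoxy groups and gives 2800 nM in this assay. A step toward lower numbers is expected, of modest size, probably near the edge of the scatter. For compound 4 the expected value in this assay is 6000 nM, within 2000 nM to 20000 nM. The step of a 1.9-fold lower number from compound 3 to compound 4 (0.27 log units; within the scatter) is thus expected to be a modest gain, and a number rather than a limit is expected.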

Compound 4, half-maximal inhibitory concentration: 4700 nM
Compound 4: middle estimate off by 1.3-fold (0.11 log units), on the high side, within the range that was stated.
By their numbers in this assay, from the lowest: compounds 1 and 4 (each within the scatter of the next); then compound 3. At a limit, above all of these: compound 2.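

In this assay, the series now has its first comparison between compounds that differ in one place: methoxy in place of hydrogen on an aromatic carbon gives a 2.4-fold lower number from compound 3 to compound 4 (0.37 log units; beyond the scatter), a modest step. The earlier compounds shown here could only hint at what a methoxy group might do here, whereas this step shows directly that adding one at this position, meta to a methoxy group and para to a large group, moves the number toward stronger inhibition and not toward weaker. The compounds shown offer no measured ground that would explain why the number moves in this direction.

Going by these compounds, what remains open is whether this gain belongs to methoxy itself or would also appear with another group at the same position, such as a hydroxyl, an amine, a fluorine atom or a longer chain like ethoxy. On these data alone, it is also open whether methoxy would produce a step of similar size at another position on this ring, or on a ring that lacks the methoxy group already present in compound 3.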